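Swapping the Furan Arm for a Pyridine Arm

The source may report more compounds than this note shows. Statements on the series, on what has been measured and on what is new or still open speak of the compounds shown alone.

In an ADME assay on MT4 cells (Homo sapiens) for cytotoxicity, read by MTT assay (on this read-out lower numbers stand for higher toxicity in this test and higher numbers for lower toxicity in this test), compound 1 `Cc1cc(C)cc(S(=O)(=O)c2c(C(=O)NC(C)C(=O)NCc3ccco3)[nH]c3ccc(Cl)cc23)c1` gives 24200 nM. Compound 2 `Cc1cc(C)cc(S(=O)(=O)c2c(C(=O)NCC(=O)NCc3ccco3)[nH]c3ccc(Cl)cc23)c1` reaches only the limit of this assay, > 50000 nM. For the measured compounds named here, the single measured step, an at least 2.0-fold higher number from compound 1 to compound 2 (0.31 log units; beyond the scatter), is bounded by the limit of > 50000 nM in this assay, at which 1 of the 2 values shown sits. Compound 3 `Cc1cc(C)cc(S(=O)(=O)c2c(C(=O)NCC(=O)NC(C)c3ccncc3)[nH]c3ccc(Cl)cc23)c1` differs from compound 2 by 1-(pyridin-4-yl)ethyl in place of (furan-2-yl)methyl on an amide-type nitrogen. Going by the values given here, no measured step touches this part of the molecule, so there is no basis in this assay to expect a shift beyond the scatter. The estimated step is therefore a number no higher from compound 2 to compound 3 (the limit leaves the size open). Compound 3 is expected to give about 50000 nM, somewhere between 20000 nM and 120000 nM.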

Compound 3, half-maximal cytotoxic concentration: 47000 nM
Compound 3: the middle estimate sits 1.1-fold (0.03 log units) above what was measured; the measured number falls inside the stated range.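

Moving from (furan-2-yl)methyl to 1-(pyridin-4-yl)ethyl on the amide-type nitrogen gives an at least 1.0-fold lower number from compound 2 to compound 3 (0.02 log units; that floor lies within the scatter). From the compounds shown here alone, the size of that step stays unknown, since the value of compound 2 is a limit and not a number: the limit of > 50000 nM in this assay, at which 1 of the 3 values shown sits. Compound 3 does give a true number, and the comparison with the earlier compound reads a 1.9-fold higher number from compound 1 to compound 3 (0.29 log units; within the scatter).

In this arm the ring and the added methyl change together, so their separate contributions remain unresolved. Going by these compounds, an amine, a carboxylic acid or a longer chain on this nitrogen also remains open.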